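Chloro on the anilide ring: two cores compared

A few compounds are considered here, and "the series" means these few. Any claim that something is new, unique, unknown or untested is made for them only; others in the source may bear on it.

Compound 1 `O=C(CCCCC(S)CCS)Nc1ccccc1` and compound 2 `O=C(CCCCC(S)CCS)Nc1ccc(Cl)cc1` share one core. In a functional assay on Bel-7402 cells (Homo sapiens) for inhibition, read by MTT assay, with a stated time of 24 h, tested at 10 ug/mL (a lower number here means less inhibition of growth, a higher number more inhibition of growth at the concentration tested), compound 1 gives 3.72% and compound 2 gives 1.16%; the change chloro in place of hydrogen on an aromatic carbon made a step of a number 2.6 percentage points lower from compound 1 to compound 2 (within the scatter). Compound 3 `CC(=O)SCCC(CCCCC(=O)Nc1ccccc1)SC(C)=O` is built on another core; the difference between the two cores is not broken down here. In this assay compound 3 is reported as "not active" (no number reported). Compound 4 `CC(=O)SCCC(CCCCC(=O)Nc1ccccc1Cl)SC(C)=O` differs from compound 3 by chloro in place of hydrogen on an aromatic carbon. This is the same kind of change as that from compound 1 to compound 2, not the same: there the place is para to a large group, here ortho to a large group. For compound 4 a step of similar small size is expected in this assay, because the like change gave a number 2.6 percentage points lower from compound 1 to compound 2 (within the scatter) and compound 3 stands at "not active" (no number reported). Compound 4 is estimated at 3%, between 0% and 12%.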

Compound 4, percent growth inhibition at one concentration: 3.09%
Compound 4: the middle estimate sits 0.1 percentage points below what was measured; the range from low to high includes it.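

No step can be read from compound 3 to compound 4: in this assay compound 3 stands as "not active" (no number reported) and compound 4 gives 3.09%. No evidence on a cause is at hand. The compounds shown leave open whether chloro ortho to a large group and chloro para to a large group differ on one core.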